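The compounds below may be only part of what the source reports. "The series", "measured", "known", "first", "only" and "open" are said of these compounds alone.

In a functional assay on CHO cells for agonist activity at Glucose-dependent insulinotropic receptor (Homo sapiens), read by a luciferase reporter and cAMP accumulation, with a stated time of 2 h (on this read-out lower numbers stand for an effect already at smaller amounts and higher numbers for an effect only at larger amounts of compound), three compounds built around a shared carbamate core have been measured. Compound 1 `CC(CC1CCN(C(=O)OC(C)(C)C)CC1)OC(=O)N1CCc2cc(S(C)(=O)=O)ccc21` gives 2600 nM, and compound 2 `CC(C)(C)OC(=O)N1CCC(C(O)COC(=O)N2CCc3cc(S(C)(=O)=O)ccc32)CC1` gives 2400 nM; these two numbers lie within the scatter of each other, so no order between them can be read. Compound 3 `CC(C)(C)OC(=O)N1CCC(CCOC(=O)N2CCc3c2ccc(S(C)(=O)=O)c3F)CC1` gives 25 nM, the lowest number of the three, and its distance to compound 2 as well as to compound 1 lies beyond the scatter, so compound 3 is the most potent of the measured set. Compound 4 `Cc1c(S(C)(=O)=O)ccc2c1CCN2C(=O)OCCC1CCN(C(=O)OC(C)(C)C)CC1` has not yet been measured. It differs from compound 3 in one place: methyl in place of fluoro on an aromatic carbon. Within the data shown here, no pair of measured compounds differs in exactly one place, so the size of such a swap on this core cannot be taken from the numbers at hand. Because compound 3 gives 25 nM and the swap touches only a single heavy atom on the fused ring system, a small step in this assay is expected for compound 4, most likely toward a somewhat higher number, a 1.6-fold higher number from compound 3 to compound 4 (0.20 log units; within the scatter). Compound 4 is therefore estimated to give about 40 nM, with a range from 12 nM to 150 nM.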

Compound 4, half-maximal effective concentration in the Glucose-dependent insulinotropic receptor assay: 770 nM
Estimate against measurement, compound 4: 19-fold (1.28 log units) below, outside the stated range (above it).
By their numbers in the Glucose-dependent insulinotropic receptor assay, from the lowest: compound 3; then compound 4; then compounds 2 and 1 (each within the scatter of the next).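

Among these compounds, the step is the first in this set that isolates a single place on the shared core. In the Glucose-dependent insulinotropic receptor assay, methyl in place of fluoro on an aromatic carbon, ortho to a methylsulfonyl group and ortho to a fused ring, gives a 31-fold higher number from compound 3 to compound 4 (1.49 log units; beyond the scatter), so this position responds strongly even though one heavy atom leaves, one enters, and the counts of hydrogen-bond donors, hydrogen-bond acceptors and net charge stay the same. In a physicochemical assay for solubility, read by HPLC, at pH 6.8 (a higher number here means a more soluble compound, a lower number a less soluble compound), compound 3 gives 0.81 ug/mL and compound 4 gives 0.17 ug/mL. The same swap also separates the two compounds in the physicochemical assay, where the change is smaller than in the agonist read-out but still lies beyond the scatter: the measured solubility of compound 3, 0.81 ug/mL, and of compound 4, 0.17 ug/mL, a 4.8-fold lower number (0.68 log units; beyond the scatter)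

The compounds shown leave open how hydrogen, chloro or a nitrile at this position would stand against fluoro and methyl, so they cannot tell whether the step follows the departure of fluoro or the arrival of methyl. They also leave open whether the difference in solubility has any bearing on the numbers in the Glucose-dependent insulinotropic receptor assay, and whether the swap would give a step of similar size on another side chain.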